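This account rests on a few compounds, and the source may have more. Where it says the series, first, only, none or still open, it means among the compounds named here.

Compound 1 `CCOC(=O)CN(Cc1cc(F)cc(F)c1)c1ccc2c(c1)OC(C)(COc1ccc(C#N)cc1)CN2C` was tested in a functional assay on HeLa cells (Homo sapiens) for antiproliferative activity, read by cell counting, with a stated time of 4 days; on this read-out lower numbers stand for stronger inhibition and higher numbers for weaker inhibition. In this assay compound 1 gives > 100000 nM, and this is a limit of the assay rather than a measured number. Two further compounds do give numbers: compound 2 `CCOC(=O)C(=O)N(Cc1cc(F)cc(F)c1)c1ccc2c(c1)OC(C)(CO)CN2C` gives 44000 nM, and compound 3 `CCOC(=O)CN(Cc1cccc(F)c1)c1ccc2c(c1)N(C)CC(C)(COc1ccc(C(=N)N)cc1)O2` gives 4600 nM. Compound 1 therefore sits at the limit of > 100000 nM in this assay, at which 1 of the 3 values shown sits, so its position is known only as a limit. Among the three measured compounds there is no pair that differs in a single place, so no measured step is available to lean on.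

Compound 4 `CCOC(=O)CN(Cc1ccc(F)cc1)c1ccc2c(c1)OC(C)(COc1ccc(C#N)cc1)CN2C` has not yet been measured. It differs from compound 1 in one change only: 4-fluorophenyl in place of 3,5-difluorophenyl on a saturated chain carbon bound to a nitrogen on an aromatic ring. For the measured compounds named here, with no measured step of this kind to guide it, the step away from the limit is estimated as an at least 1.6-fold lower number from compound 1 to compound 4 (0.22 log units; that floor lies within the scatter), an expected change that is modest rather than large. Compound 4 is accordingly expected to give about 60000 nM, with a range from 15000 nM to 200000 nM, and a real chance that the assay again reports only a limit.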

Compound 4, half-maximal inhibitory concentration: > 100000 nM
Compound 4: a limit, no number; the forecaster's own chance of this, stated with the estimate: 45%; middle value at least 1.6-fold (0.22 log units) away from the limit.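

In this assay, for the compounds shown here, compound 1 and compound 4 both end at a limit of the assay rather than at a measured number, so no step between them can be read. The compounds shown leave open whether 4-fluorobenzyl in place of 3,5-difluorobenzyl changes inhibition at all, and by how much.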